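The source may report more compounds than this note shows. Statements on the series, on what has been measured and on what is new or still open speak of the compounds shown alone.

Measured compounds:
- compound 1, `CC1=C(CC(=O)OCCOc2no[n+]([O-])c2S(=O)(=O)c2ccccc2)c2cc(F)ccc2/C1=C\c1ccc([S+](C)[O-])cc1`: 27900 nM
- compound 2, `CC1=C(CC(=O)OCCCCCCOc2no[n+]([O-])c2S(=O)(=O)c2ccccc2)c2cc(F)ccc2/C1=C\c1ccc([S+](C)[O-])cc1`: 6100 nM

In a functional assay on PC-3 cells (Homo sapiens) for cytotoxicity, read by crystal violet staining, with a stated time of 72 h (a lower number here means a stronger inhibitor, a higher number a weaker inhibitor), compound 1 gives 27900 nM, the highest of the two numbers. Its nearest neighbour is compound 2, which gives 6100 nM in this assay, a gap that lies beyond the usual scatter. Within the data shown here, no step between measured compounds is available for the change now considered.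

Compound 3, `CSc1ccc(/C=C2/C(C)=C(CC(=O)OCCOc3no[n+]([O-])c3S(=O)(=O)c3ccccc3)c3cc(F)ccc32)cc1`, is not yet measured. It differs from compound 1 in one place: a group of 2 heavy atoms (1 carbon, 1 sulfur; no ring) in place of a group of 3 heavy atoms (1 carbon, 1 oxygen, 1 sulfur; no ring), on an aromatic carbon, on an aromatic carbon of a six-membered aromatic ring of carbon only, para to a large group. Among the measured compounds shown here, nothing among the measured pairs shows this exchange, so the direction rests on expectation alone. Compound 3 is expected to give a somewhat lower number than compound 1 in this assay, a step of modest size, a 2.3-fold lower number from compound 1 to compound 3 (0.37 log units; beyond the scatter), that may still fall near the edge of the scatter. The estimate for compound 3 is 12000 nM, within 4000 nM to 35000 nM.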

Compound 3, half-maximal inhibitory concentration: 41400 nM
Compound 3: the middle estimate sits 3.5-fold (0.54 log units) below what was measured, and the stated range ends below it.
By their numbers in this assay, from the lowest: compound 2; then compounds 1 and 3 (each within the scatter of the next).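

On the six-membered aromatic ring of carbon only, para to a large group, exchanging the oxygen-bearing sulfur group of compound 1 for methylsulfanyl gives, in this assay, a 1.5-fold higher number from compound 1 to compound 3 (0.17 log units; within the scatter). Among these compounds, this is the first direct reading at this position, and it shows that the two groups cannot be told apart here: within the scatter, the oxygen that leaves with this exchange makes no measurable difference in this pair. No measurement is at hand that could explain this result.

What the compounds shown leave open is whether a methylsulfonyl group or an amine at this place would separate from these two. They also leave open whether methylsulfanyl would read the same way on the longer chain of compound 2, which gives 6100 nM.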